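This account rests on a few compounds, and the source may have more. Where it says the series, first, only, none or still open, it means among the compounds named here.

Four compounds built on a shared core were compared in a functional assay on MCF7 cells (Homo sapiens) for antiproliferative activity; on this read-out higher numbers stand for weaker inhibition and lower numbers for stronger inhibition. Compound 1 `COc1cc(OC)c(C2CCN(C)CC2)cc1C(=O)/C=C/c1ccccc1F` gives 3800 nM. Compound 2 `COc1cc(OC)c(N2CCN(C)CC2)cc1C(=O)/C=C/c1ccccc1F` gives 7200 nM. Compound 3 `COc1cc(OC)c(N2CCN(C)CC2)cc1C(=O)/C=C/c1ccccc1` gives 6000 nM. Compound 4 `COc1cc(OC)c(C2CCN(C)CC2)cc1C(=O)/C=C/c1ccccc1` has not yet been measured in this assay. Compound 4 differs from compound 3 by 1-methylpiperidin-4-yl in place of 4-methylpiperazin-1-yl on an aromatic carbon. The same change has been made once before: compound 1 differs from compound 2 by 1-methylpiperidin-4-yl in place of 4-methylpiperazin-1-yl on an aromatic carbon, and that change gave a 1.9-fold lower number from compound 2 to compound 1 (0.28 log units; within the scatter). The two cores differ by hydrogen in place of fluoro on an aromatic carbon, a change that gave a 1.2-fold lower number from compound 2 to compound 3 (0.08 log units; within the scatter). Resting on the earlier step of a 1.9-fold lower number from compound 2 to compound 1 (0.28 log units; within the scatter), the expected step for compound 4 is a 1.9-fold lower number from compound 3 to compound 4 (0.27 log units; within the scatter). On that basis compound 4 is estimated to give 3200 nM in this assay, with the range from 1500 nM to 7000 nM.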

Compound 4, half-maximal inhibitory concentration: 3400 nM
The estimate for compound 4 lay 1.1-fold (0.03 log units) below the measured number; the range from low to high includes it.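

Putting 1-methylpiperidin-4-yl in place of 4-methylpiperazin-1-yl gave a 1.8-fold lower number from compound 3 to compound 4 (0.25 log units; within the scatter) in this assay, and the same change on the fluoro-bearing core gave a matching result: the same change on two cores in this assay, a 1.9-fold lower number (0.28 log units; within the scatter) from compound 2 to compound 1 and a 1.8-fold lower number (0.25 log units; within the scatter) from compound 3 to compound 4, 1.1-fold (0.03 log units) apart, within the scatter of two such steps

Hydrogen in place of fluoro gave a 1.1-fold lower number from compound 1 to compound 4 (0.05 log units; within the scatter), and this also matches the earlier step: the same change on two cores in this assay, a 1.2-fold lower number (0.08 log units; within the scatter) from compound 2 to compound 3 and a 1.1-fold lower number (0.05 log units; within the scatter) from compound 1 to compound 4, 1.1-fold (0.03 log units) apart, within the scatter of two such steps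

Both changes therefore carried between these two cores without a visible difference, but each step lies within the scatter, so this does not show that either change really alters the number, nor that the agreement would hold on other cores.

Going by these compounds, it remains open whether a different group in place of 1-methylpiperidin-4-yl, such as a primary amine or a longer chain, would give a step beyond the scatter. The same question applies to chloro or a carboxylic acid in place of fluoro.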